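The source may hold more compounds than are shown below. What is called first, only, known or untested is meant among the compounds shown, and "the series" means these compounds.

Measured in a functional assay on DU-145 cells (Homo sapiens) for inhibition, read by trypan blue exclusion, with a stated time of 96 h; on this read-out higher numbers stand for weaker inhibition of growth and lower numbers for stronger inhibition of growth:
- compound 1 `CCOc1cc(/C=C(\C(=O)c2ccc(Cl)cc2)S(=O)(=O)Cc2ccc(Cl)cc2)ccc1O`: 10000 nM
- compound 2 `Cc1ccc(/C=C(\C(=O)c2ccc(Cl)cc2)S(=O)(=O)Cc2ccc(F)cc2)s1`: 50000 nM
- compound 3 `Cc1ccsc1/C=C(\C(=O)c1ccc(Cl)cc1)S(=O)(=O)Cc1ccc(Cl)cc1`: 25000 nM

Compound 3 lies within the usual scatter of compound 2 and gives a higher number than compound 1. Compound 4 `Cc1ccc(/C=C(\C(=O)c2ccc(Cl)cc2)S(=O)(=O)Cc2ccc(Cl)cc2)s1` has 5-methylthiophen-2-yl in place of 3-methylthiophen-2-yl on a double-bonded chain carbon bound to a double-bonded chain carbon.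

Among the measured compounds shown here, the one measured step at this place is a 2.5-fold higher number from compound 1 to compound 3 (0.40 log units; beyond the scatter). It is modest, and it swaps a different group, so it only loosely bounds what a change here can do. For the measured compounds named here, no measured pair isolates the move of the methyl group. Compound 2 carries the same 5-methylthiophen-2-yl group and gives 50000 nM, but it differs from compound 4 elsewhere. No step beyond the scatter is therefore expected in this assay. The expected change is a 1.2-fold higher number from compound 3 to compound 4 (0.08 log units; within the scatter). For compound 4 the estimated value is 30000 nM, with an expected range of 12000 nM to 70000 nM.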

Compound 4, concentration for 50% growth inhibition: 1000 nM
Compound 4: the middle estimate sits 30-fold (1.48 log units) above what was measured; the measured number lies below the stated range.
By their numbers in this assay, from the lowest: compound 4; then compound 1; then compounds 3 and 2 (each within the scatter of the next).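

In this assay, the place on a double-bonded chain carbon bound to a double-bonded chain carbon proves highly sensitive to the isomer present: 5-methylthiophen-2-yl in place of 3-methylthiophen-2-yl, with the same atoms joined differently, gives a large step (a 25-fold lower number from compound 3 to compound 4 (1.40 log units; beyond the scatter)), and replacing 3-ethoxy-4-hydroxyphenyl with the same group also lowers the number (a 10-fold lower number from compound 1 to compound 4 (1.00 log units; beyond the scatter)). The 5-methylthiophen-2-yl group does not secure a low number by itself, since chloro in place of fluoro on an aromatic carbon also gives a large step (a 50-fold lower number from compound 2 to compound 4 (1.70 log units; beyond the scatter)). Nothing measured here explains either large step.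

Going by these compounds, it remains open whether the low number of compound 4 survives an ethyl group, an amine or a carboxylic acid in place of the methyl. On these data alone, it is also open whether the chloro for fluoro step recurs with 3-methylthiophen-2-yl or 3-ethoxy-4-hydroxyphenyl at the chain carbon.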